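Ethoxy to cyclopropylmethoxy on the way to compound 4

This account rests on a few compounds, and the source may have more. Where it says the series, first, only, none or still open, it means among the compounds named here.

Measured in an ADME assay on the whole organism (plasma, Mus musculus, strain CD1), read by LC-MS, with a stated time of 24 h; on this read-out higher numbers stand for a larger free fraction and lower numbers for a smaller free fraction:
compound 1 `CCOc1cc2[nH]c(Cc3nn(CC(=O)O)c(=O)c4ccccc34)nc2cc1Cl` gives 0.051
compound 2 `O=C(O)Cc1nn(Cc2cn3cc(OCC4CC4)c(Cl)cc3n2)c2ccccc2c1=O` gives 0.045
compound 3 `C[C@H](C(=O)O)c1nn(Cc2cn3cc(OCC4CC4)c(Cl)cc3n2)c2ccccc2c1=O` gives 0.032

The numbers for compound 1, compound 2 and compound 3 all lie within the scatter of one another, so compound 1 is not set apart from either neighbour in this assay. Compound 4 `O=C(O)Cn1nc(Cc2nc3cc(Cl)c(OCC4CC4)cc3[nH]2)c2ccccc2c1=O` keeps the core of compound 1 and exchanges one group, ethoxy to cyclopropylmethoxy, with cyclopropyl in place of methyl on a saturated chain carbon bound to an oxygen on an aromatic ring. For the measured compounds named here, the only measured step, a 1.4-fold lower number from compound 2 to compound 3 (0.15 log units; within the scatter), stays within the scatter. It places a methyl on a saturated chain carbon bound to an aromatic carbon and a carbonyl carbon, so it bears on this change only loosely. Compound 2 already carries cyclopropylmethoxy, on a different core, and gives 0.045 in this assay. Going by the values given here, no measured pair isolates the change, and no step beyond the scatter is expected. An estimated 1.3-fold lower number from compound 1 to compound 4 (0.11 log units; within the scatter) is expected, within the scatter. Compound 4 is estimated at 0.04 (expected range 0.022 to 0.07) .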

Compound 4, unbound fraction: 0.012
For compound 4 the middle estimate is 3.3-fold (0.52 log units) above the measured one, and the stated range ends above it.
By their numbers in this assay, from the lowest: compound 4; then compounds 3, 2 and 1 (each within the scatter of the next).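

In this assay, for the compounds shown here, the exchange of ethoxy for cyclopropylmethoxy on the core of compound 1 gives a 4.3-fold lower number from compound 1 to compound 4 (0.63 log units; beyond the scatter), the first step in this set that lies beyond the scatter. Going by these compounds alone, the only earlier step stayed within the scatter and concerned a different place, so this is the first sign that the free fraction responds to a change at this position, on a saturated chain carbon bound to an oxygen on an aromatic ring. Nothing measured here accounts for the step.

From the compounds shown here alone, it remains open whether the cyclopropyl ring itself matters or whether an open chain such as propyl or isopropyl in the same place would give a similar number. Also open, going by these compounds, is how an amine or a hydroxyl on that chain would read in this assay.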